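A few compounds are considered here, and "the series" means these few. Any claim that something is new, unique, unknown or untested is made for them only; others in the source may bear on it.

Measured in a functional assay on MCF7 cells (Homo sapiens) for cytotoxicity, read by MTT assay, with a stated time of 72 h; on this read-out higher numbers stand for weaker inhibition and lower numbers for stronger inhibition:

- Compound 1 `Nc1cc2nc(-c3ccccc3)nn(-c3ccccc3)c-2cc1=O`: 950 nM
- Compound 2 `O=c1cc2n(-c3ccccc3)nc(-c3ccccc3)nc-2cc1N1CCCC1`: 360 nM
- Compound 3 `CC(=O)Nc1cc2nc(-c3ccccc3)nn(-c3ccccc3)c-2cc1=O`: > 5000 nM

Compound 3 has no number, only a limit of the assay, > 5000 nM. Compound 4 `COc1cc2nc(-c3ccccc3)nn(-c3ccccc3)c-2cc1=O` carries methoxy in place of acetamido on an aromatic carbon. Among the measured compounds shown here, two measured steps bear on this change, both beyond the scatter and both ending on acetamido: an at least 5.2-fold higher number from compound 1 to compound 3 (0.72 log units; beyond the scatter) and the large at least 13-fold higher number from compound 2 to compound 3 (1.14 log units; beyond the scatter). The third, a 2.6-fold lower number from compound 1 to compound 2 (0.42 log units; beyond the scatter), is modest. For the measured compounds named here, no measured compound carries methoxy, so the size of the step remains uncertain, but its direction is expected to be towards a lower number. The expected change is an at least 5.0-fold lower number from compound 3 to compound 4 (0.69 log units; beyond the scatter). Compound 4 is estimated at 1000 nM, with an expected range from 300 nM to 4000 nM.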

Compound 4, half-maximal inhibitory concentration: > 5000 nM
Compound 4 gave a limit, no number; the forecaster's own chance of this, stated with the estimate: 10%; middle value at least 5.0-fold (0.69 log units) away from the limit.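

Methoxy, like acetamido, fails to give a readable value at this position in this assay, so removing the hydrogen-bond donor of acetamido does not recover activity. The change to methoxy gives an at least 5.2-fold higher number from compound 1 to compound 4 (0.72 log units; beyond the scatter) and an at least 13-fold higher number from compound 2 to compound 4 (1.14 log units; beyond the scatter), so among these four compounds, only amino and pyrrolidin-1-yl give numbers. The step between acetamido and methoxy cannot be read, because both compounds sit at the same limit of the assay: the limit of > 5000 nM in this assay, at which 2 of the 4 values shown sit.

Going by these compounds, whether a larger cyclic amine such as piperidine or morpholine would match pyrrolidin-1-yl remains open. So does the effect of a simple dimethylamino group or a hydroxyl group here.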